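Amide nitrogen substitution on the shared core

The source may report more compounds than this note shows. Statements on the series, on what has been measured and on what is new or still open speak of the compounds shown alone.

Compound 2 `NC(=O)c1cc(-c2ccc(NS(=O)(=O)c3cccc(Cl)c3Cl)cc2)nc2[nH]ncc12` gives 236 nM in an assay for inhibition of serine/threonine-protein kinase Sgk1 (Homo sapiens), with stated times of 30 min and 60 min, in the presence of a further agent that is not named here (on this read-out lower numbers stand for stronger inhibition and higher numbers for weaker inhibition), the highest of the two numbers in hand; the nearest is compound 1 `O=C(NC1CCN(CC2CC2)C1)c1cc(-c2ccc(NS(=O)(=O)c3cccc(Cl)c3Cl)cc2)nc2[nH]ncc12`, which in this assay gives 35 nM. Going by the values given here, the one measured step on this nitrogen is a 6.7-fold higher number from compound 1 to compound 2 (0.83 log units; beyond the scatter). Compound 3 `NCCNC(=O)c1cc(-c2ccc(NS(=O)(=O)c3cccc(Cl)c3Cl)cc2)nc2[nH]ncc12` carries 2-aminoethyl in place of hydrogen on an amide-type nitrogen. Among the compounds with values here, a lower number is expected for compound 3 because a 6.7-fold higher number from compound 1 to compound 2 (0.83 log units; beyond the scatter) shows that stripping the substituent off this nitrogen raised the number, though a smaller move than the reverse of that step is expected, as the entering group is not the one compound 1 carries. Compound 3 is estimated at 90 nM, within 30 nM to 270 nM, an expected step of a 2.6-fold lower number from compound 2 to compound 3 (0.42 log units; beyond the scatter).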

Compound 3, half-maximal inhibitory concentration: < 1 nM
Compound 3 was reported as a limit; the forecaster's own chance of this, stated with the estimate: 2%; middle value at least 90-fold (1.95 log units) away from the limit.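

Putting 2-aminoethyl on this amide-type nitrogen gives an at least 230-fold lower number from compound 2 to compound 3 (2.37 log units; beyond the scatter), so a small open chain can do far more here than the step from the unsubstituted amide to compound 1 suggested. Exchanging 1-(cyclopropylmethyl)pyrrolidin-3-yl for 2-aminoethyl gives an at least 35-fold lower number from compound 1 to compound 3 (1.54 log units; beyond the scatter), so the ring-bearing group is not required for strong inhibition. Compound 3 stands as a limit in this assay, not a number, and both steps are therefore minimum sizes: the limit of < 1 nM in this assay, at which 1 of the 3 values shown sits.

From the compounds shown here alone, how far compound 3 lies beyond that limit remains open. Also open, going by these compounds, is whether the terminal amine or the chain matters more, which a hydroxyethyl or a longer aminopropyl chain on this nitrogen would help separate.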